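Compound 4 after the limit of compound 3

The source may report more compounds than this note shows. Statements on the series, on what has been measured and on what is new or still open speak of the compounds shown alone.

Measured in a functional assay on MCF7 cells (Homo sapiens) for antiproliferative activity, read by MTT assay, with a stated time of 72 h (on this read-out lower numbers stand for stronger inhibition and higher numbers for weaker inhibition), as follows
- compound 1 `CCCSc1nc(N/N=C/c2cccnc2)c2nnn(Cc3ccccc3)c2n1` gives 58700 nM
- compound 2 `CCCSc1nc(N/N=C/c2ccc(Cl)cc2)c2nnn(Cc3ccccc3)c2n1` gives > 64000 nM (a limit of the assay)
- compound 3 `CCCSc1nc(N/N=C/c2cccs2)c2nnn(Cc3ccccc3)c2n1` gives > 64000 nM (a limit of the assay)

Compound 3 thus stands at a limit and not at a number. That is the limit of > 64000 nM in this assay, at which 2 of the 3 values shown sit. Compound 4 `CCCSc1nc(N/N=C/c2ccc(N(C)C)cc2)c2nnn(Cc3ccccc3)c2n1` differs from it by 4-(dimethylamino)phenyl in place of thiophen-2-yl on a carbon with a double bond to nitrogen, with 4-(dimethylamino)phenyl in place of thiophen-2-yl on a carbon with a double bond to nitrogen. Three swaps at this same carbon bear on the change. They are an at least 1.0-fold higher number from compound 1 to compound 2 (0.03 log units; that floor lies within the scatter), an at least 1.0-fold higher number from compound 1 to compound 3 (0.03 log units; that floor lies within the scatter) and a step that the two limits leave unreadable from compound 2 to compound 3. The first two floors lie within the scatter and the third cannot be read, so no step beyond the scatter is expected in this assay. The estimated step is a number no higher from compound 3 to compound 4 (the limit leaves the size open). Compound 4 is expected at 64000 nM, within an estimated range from 30000 nM to 130000 nM.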

Compound 4, half-maximal inhibitory concentration: 12200 nM
Compound 4: middle estimate off by 5.2-fold (0.72 log units), on the high side; measured number below the stated range.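

In this assay, swaps on this carbon with a double bond to nitrogen now give steps beyond the scatter, which none of the earlier swaps had done: 4-(dimethylamino)phenyl brings an at least 5.2-fold lower number from compound 3 to compound 4 (0.71 log units; beyond the scatter), and dimethylamino in place of chloro brings an at least 5.2-fold lower number from compound 2 to compound 4 (0.71 log units; beyond the scatter). For the compounds shown here, the group also brings a 4.8-fold lower number from compound 1 to compound 4 (0.68 log units; beyond the scatter), the only one of these steps with a full size. The other two are only floors because compound 2 and compound 3 each stand at a limit: the limit of > 64000 nM in this assay, at which 2 of the 4 values shown sit.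

The compounds shown leave open whether a primary amine, a morpholine or a methoxy group in place of dimethylamino would keep this step.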